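The source may report more compounds than this note shows. Statements on the series, on what has been measured and on what is new or still open speak of the compounds shown alone.

Compound 1 `c1ccc2c(c1)CCC2NC1CCN(CCCc2c[nH]c3ccc(-n4cnnc4)cc23)CC1`: 8.9 nM
Compound 2 `C[C@@H](NC1CCN(CCCc2c[nH]c3ccc(-n4cnnc4)cc23)CC1)c1ccccc1`: 0.4 nM
Compound 3 `CC(=O)Nc1ccc([C@H](C)NCC2CCN(CCCc3c[nH]c4ccc(-n5cnnc5)cc34)CC2)cc1`: 0.6 nM

All three compounds were measured in an assay on CHO cells for displacement of a labelled ligand from 5-hydroxytryptamine receptor 1D (Homo sapiens); a lower number here means a stronger inhibitor, a higher number a weaker inhibitor. Compound 1 shows the highest number of the three; compound 3 lies nearest to it and compound 2 furthest from it. One single-site step among the measured compounds bears on the change considered here: a 22-fold lower number from compound 1 to compound 2 (1.35 log units; beyond the scatter), a large step. Compound 4 `c1ccc(CNCC2CCN(CCCc3c[nH]c4ccc(-n5cnnc5)cc34)CC2)cc1` carries (benzylamino)methyl in place of (2,3-dihydro-1H-inden-1-yl)amino on a saturated ring carbon. Like compound 2, it gives up the 2,3-dihydro-1H-inden-1-yl group for a single six-membered aromatic ring; unlike compound 2, it also places a methylene between the saturated ring carbon and the amine nitrogen, an arrangement that compound 3 shares. For the measured compounds named here, no measured step separates that methylene alone, but compound 3 gives 0.6 nM, a number in the same region as compound 2. The expectation for compound 4 is therefore a clear downward step, a 5.9-fold lower number from compound 1 to compound 4 (0.77 log units; beyond the scatter), somewhat smaller than the step to compound 2 since the methyl on the benzylic carbon is absent. Compound 4 is estimated at 1.5 nM, with a range of 0.4 nM to 6 nM.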

Compound 4, half-maximal inhibitory concentration: 1.6 nM
Beside the measured number, compound 4's estimate is 1.1-fold (0.03 log units) below it; low and high end bracket the measured number.
By their numbers in this assay, from the lowest: compounds 2 and 3 (each within the scatter of the next); then compound 4; then compound 1.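

In this assay, the (benzylamino)methyl group still gives a clear gain over (2,3-dihydro-1H-inden-1-yl)amino at this saturated ring carbon, with a 5.6-fold lower number from compound 1 to compound 4 (0.75 log units; beyond the scatter), so the gain does not depend on a substituted benzylic carbon. That gain is only partial, however, as the other two comparisons show a 4.0-fold higher number from compound 2 to compound 4 (0.60 log units; beyond the scatter) and a 2.7-fold higher number from compound 3 to compound 4 (0.43 log units; beyond the scatter), placing compound 4 above both compounds that carry a methyl on the benzylic carbon. No evidence is available that explains these differences.

The steps from compound 2 and compound 3 each combine more than one structural difference, so the share of the methyl, the added methylene and the acetamido group stays unresolved. On these data alone, it also remains open how a phenethyl group on the amine nitrogen would compare with the benzyl group of compound 4.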